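The source may report more compounds than this note shows. Statements on the series, on what has been measured and on what is new or still open speak of the compounds shown alone.

Compound 2 `CNC(=O)c1cc(C(=O)NC2CC2)cn(CC2CCOCC2)c1=O` carries an (oxan-4-yl)methyl group on an aromatic nitrogen of the shared core. In a physicochemical assay for solubility (on this read-out lower numbers stand for lower solubility and higher numbers for higher solubility), compound 2 gives >= 165 ug/mL, which is a limit of the assay rather than a number. Compound 1 `CNC(=O)c1cc(C(=O)NC2CC2)c(C)n(Cc2ccccc2)c1=O` gives >= 126 ug/mL, also a limit. Compound 3 `CNC(=O)c1cc(C(=O)NC2CC2)cn([C@H](C)c2ccccc2)c1=O` gives >= 168 ug/mL, again a limit. For the measured compounds named here, the step from compound 2 to compound 3 is a step that the two limits leave unreadable from compound 2 to compound 3, because the two limits the limit of >= 165 ug/mL in this assay, at which 1 of the 3 values shown sits, and the limit of >= 168 ug/mL in this assay, at which 1 of the 3 values shown sits, leave nothing to read, so no measured step bears on the new change. Compound 4 `CNC(=O)c1cc(C(=O)NC2CC2)cn(Cc2nccc3[nH]ccc23)c1=O` differs from compound 2 by a group of 9 heavy atoms (7 carbon, 2 nitrogen; one five-membered aromatic ring with 1 hetero atom, one six-membered aromatic ring with 1 hetero atom) in place of a group of 6 heavy atoms (5 carbon, 1 oxygen; one six-membered non-aromatic ring with 1 hetero atom), on a saturated chain carbon bound to an aromatic nitrogen. The expected step of an at least 1.8-fold lower number from compound 2 to compound 4 (0.26 log units; that floor lies within the scatter) therefore rests on the structural change alone. Compound 4 is estimated at 90 ug/mL, with a range from 25 ug/mL to 250 ug/mL.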

Compound 4, solubility: 73 ug/mL
Compound 4: middle estimate off by 1.2-fold (0.09 log units), on the high side; the measured number falls inside the stated range.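

For the compounds shown here, compound 4 gives the first true number at this position, where the earlier compounds gave only limits and their step cannot be read. In this assay, the group with a five-membered and a six-membered aromatic ring, in place of oxan-4-yl on a saturated chain carbon bound to an aromatic nitrogen, brings an at least 2.2-fold lower number from compound 2 to compound 4 (0.35 log units; beyond the scatter), so a change here can move the read-out. Nothing measured here accounts for that step.

The compounds shown leave open which of the two aromatic rings matters. They also leave open how an amine or a carboxylic acid at this place would read.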